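A few compounds are considered here, and "the series" means these few. Any claim that something is new, unique, unknown or untested is made for them only; others in the source may bear on it.

Compound 1, with the structure `O=C(Nc1cccc(Oc2ccccn2)c1)C1CCCN(C(=O)c2cc(C(F)(F)F)cc(C(F)(F)F)c2)C1`, is one of three compounds tested in an ADME assay on PC-3 cells (Homo sapiens) for cytotoxicity, read by WST assay, tested at 100 uM; on this read-out lower numbers stand for less inhibition and higher numbers for more inhibition at the one concentration tested (going by the name of the read-out). In this assay compound 1 gives 0%. Compound 2, with the structure `O=C(Nc1cccc(Oc2ccccc2)c1)C1CCCN(C(=O)c2cccc(-c3ccco3)c2)C1`, gives 0% in this assay, and compound 3, with the structure `Cc1nc(-c2cccc(C(=O)N3CCCC(C(=O)Nc4ccc(Cl)cc4)C3)c2)no1`, gives 0%. At the digits reported, compound 1 stands level with both compound 2 and compound 3, and the differences between the three values lie within the usual scatter of this kind of measurement. No pair among these three compounds differs in only one place, so no single-point step between measured compounds is available to calibrate what a structural change does on this read-out.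

Compound 4, with the structure `CCc1cccc(NC(=O)C2CCCN(C(=O)c3cc(C(F)(F)F)cc(C(F)(F)F)c3)C2)c1`, is the next compound to be measured. It differs from compound 1 as follows: ethyl in place of (pyridin-2-yl)oxy on an aromatic carbon. With all three measured compounds sitting at the same value within the scatter, there is nothing in the data to suggest that this change moves the read-out. Compound 4 is therefore expected to show no step beyond the scatter, with the estimated step of no change at the digits printed from compound 1 to compound 4 (within the scatter). The estimate for compound 4 in this assay is 0%, with a range from -5% to 12%.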

Compound 4, a percentage reported as inhibition, at one concentration (the size of the read-out at that concentration, not a potency): 0%
The estimate for compound 4 equals the measured number at the digits printed; the measured number falls inside the stated range.
By their numbers in this assay, from the lowest: compounds 1, 2, 3 and 4 (each within the scatter of the next).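

In this assay the series now has its first step between compounds that differ in one place, and it reads no change at the digits printed from compound 1 to compound 4 (within the scatter). At this aromatic carbon, meta to a large group, ethyl thus stands in for (pyridin-2-yl)oxy without any step beyond the scatter, even though the change removes the six-membered aromatic ring and the hydrogen-bond acceptors of the group that leaves, so this read-out does not depend on that ring or those acceptors in this pair. No measured evidence is available that would account for this result.

As far as these compounds go, whether an amine or a carboxylic acid on the same aromatic carbon would shift the read-out remains open, and a single step that shows no change says nothing about such groups. With compound 4 at 0% and compound 1 at 0% in this assay, the pair also leaves open what a change at this position would do in a compound that gives a higher number on this read-out.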